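The compounds below may be only part of what the source reports. "The series", "measured", "known", "first", "only" and "open" are said of these compounds alone.

Working notes on the series, read in a functional assay for inhibition, with Homo sapiens as the target; on this read-out lower numbers stand for tighter binding and higher numbers for weaker binding. Compound 1 (`O=C(O)CC/C=C\CC1COC(c2ccc([N+](=O)[O-])cc2)OC1c1cccnc1`) gives 933 nM, compound 2 (`O=C(O)CC/C=C\CC1COC(c2ccc(Cl)cc2Cl)OC1c1cccnc1`) gives 891 nM and compound 3 (`O=C(O)CC/C=C\CC1COC(c2cccnc2)OC1c1cccnc1`) gives 759 nM. Compound 3 therefore stands within the scatter of both others. Compound 4 (`O=C(O)CC/C=C\CC1COC(c2ccsc2)OC1c1cccnc1`) carries thiophen-3-yl in place of pyridin-3-yl on a saturated ring carbon. Three measured swaps at this same place bear on it: a 1.0-fold lower number from compound 1 to compound 2 (0.02 log units; within the scatter), a 1.2-fold lower number from compound 1 to compound 3 (0.09 log units; within the scatter) and a 1.2-fold lower number from compound 2 to compound 3 (0.07 log units; within the scatter). All three lie within the scatter. Going by the values given here, no measured compound has a five-membered aromatic ring at this place, which leaves that change untested. No step beyond the scatter is expected in this assay. The expected step is a 1.1-fold higher number from compound 3 to compound 4 (0.02 log units; within the scatter). The estimate for compound 4 is 800 nM, with an expected range from 400 nM to 1600 nM.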

Compound 4, dissociation constant: 1580 nM
For compound 4 the middle estimate is 2.0-fold (0.30 log units) below the measured one; the range from low to high includes it.
By their numbers in this assay, from the lowest: compounds 3, 2, 1 and 4 (each within the scatter of the next, the first and the last beyond it).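

In this assay, thiophen-3-yl brings the first five-membered aromatic ring to this saturated ring carbon between two ring oxygen atoms, and the series shows its first step beyond the scatter (a 2.1-fold higher number from compound 3 to compound 4 (0.32 log units; beyond the scatter)), so this place is not wholly indifferent to its group. Against the other two groups the change stays within the scatter (a 1.8-fold higher number from compound 2 to compound 4 (0.25 log units; within the scatter); a 1.7-fold higher number from compound 1 to compound 4 (0.23 log units; within the scatter)), and the step is modest and read only against pyridin-3-yl. No evidence at hand bears on this step.

Open, going by these compounds, is whether the step belongs to thiophen-3-yl alone or to five-membered aromatic rings generally. A furan-3-yl group, with oxygen in place of sulfur, would bear on that.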